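The source may report more compounds than this note shows. Statements on the series, on what has been measured and on what is new or still open speak of the compounds shown alone.

Three compounds have a measured number in a functional assay on DU-145 cells (Homo sapiens) for inhibition, read by trypan blue exclusion, with a stated time of 96 h; on this read-out higher numbers stand for weaker inhibition of growth and lower numbers for stronger inhibition of growth. Compound 3 `Cc1ccc(CS/C(=C/c2ccc(F)c(C)c2)C(=O)c2ccc(Cl)cc2)cc1` gives 25000 nM, level with compound 1 `Cc1ccc(S(=O)(=O)/C(=C/c2ccc(O)c([N+](=O)[O-])c2)C(=O)c2ccc(Cl)cc2)cc1` at 25000 nM, and these two share the highest number of the three. Compound 2 `COc1ccc(/C=C(/SCc2ccc(F)cc2)C(=O)c2ccc(Cl)cc2)c(OC)c1OC` gives a lower number, 10000 nM, and that gap from compound 3 lies beyond the usual scatter.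

Compound 4 `Cc1ccc(CS/C(=C/c2cc(C)ccc2C)C(=O)c2ccc(Cl)cc2)cc1` differs from compound 3 in one place, with 2,5-dimethylphenyl in place of 4-fluoro-3-methylphenyl on a double-bonded chain carbon bound to a double-bonded chain carbon. Among the measured compounds shown here, no two measured compounds differ in only one place, so no measured step shows what a swap of this kind does. The expectation therefore starts from compound 3 at 25000 nM and assumes no shift beyond the scatter. The expected step is a 1.3-fold lower number from compound 3 to compound 4 (0.10 log units; within the scatter), an estimate and not a measurement. For compound 4 the estimated value is 20000 nM, with an expected range from 8000 nM to 50000 nM.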

Compound 4, concentration for 50% growth inhibition: 10000 nM
For compound 4 the middle estimate is 2.0-fold (0.30 log units) above the measured one, and the stated range covers the measured number.
By their numbers in this assay, from the lowest: compounds 2 and 4 (each within the scatter of the next); then compounds 1 and 3 (each within the scatter of the next).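

In this assay, 2,5-dimethylphenyl in place of 4-fluoro-3-methylphenyl on a double-bonded chain carbon bound to a double-bonded chain carbon gives a 2.5-fold lower number from compound 3 to compound 4 (0.40 log units; beyond the scatter). Among the compounds shown here, this is the first one-place comparison in the set, and it shows that growth inhibition responds to what this aryl group carries, though the step is modest. The two groups have the same heavy-atom count, one aromatic carbon ring each, and no hydrogen-bond donors or acceptors, so those counts do not distinguish them. No measurement here accounts for the step.

The compounds shown do not separate the loss of the fluorine from the change in the methyl groups, as both come together in this swap. As far as these compounds go, how an amine or a carboxylic acid on this ring would read also stays open.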